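This account rests on a few compounds, and the source may have more. Where it says the series, first, only, none or still open, it means among the compounds named here.

Compound 1 `O=C(Nc1cccc(-c2oc3cc(-c4ccc(F)cc4)ccc3c(=O)c2O)c1)c1ccc(F)cc1F` is weak in a functional assay on HepG2 cells (Homo sapiens) for antiproliferative activity, read by CCK-8 assay, with a stated time of 72 h (a lower number here means a stronger inhibitor, a higher number a weaker inhibitor), where compound 1 gives 26400 nM. Its number is the largest of the three measured, though the gaps to its neighbours are small: a 1.3-fold lower number from compound 1 to compound 3 (0.11 log units; within the scatter) and a 1.7-fold lower number from compound 1 to compound 2 (0.23 log units; within the scatter). Compound 2 `O=C(Nc1cccc(-c2oc3cc(-c4ccc(F)cc4)ccc3c(=O)c2O)c1)c1cccc(F)c1` gives 15500 nM and compound 3 `CCc1ccc(C(=O)Nc2cccc(-c3oc4cc(-c5ccc(F)cc5)ccc4c(=O)c3O)c2)cc1` gives 20600 nM; a 1.3-fold higher number from compound 2 to compound 3 (0.12 log units; within the scatter). Compound 4 `Cc1cc(C)cc(C(=O)Nc2cccc(-c3oc4cc(-c5ccc(F)cc5)ccc4c(=O)c3O)c2)c1` differs from compound 1 only on the carbonyl carbon: 3,5-dimethylphenyl in place of 2,4-difluorophenyl on a carbonyl carbon. Every measured exchange of the aryl group on that carbonyl carbon has stayed within the scatter, so no step beyond the scatter is expected here either, in either direction. For compound 4 a value of 20000 nM is therefore expected, between 8000 nM and 50000 nM, amounting to an expected step of a 1.3-fold lower number from compound 1 to compound 4 (0.12 log units; within the scatter).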

Compound 4, half-maximal inhibitory concentration: 13400 nM
Compound 4: middle estimate off by 1.5-fold (0.17 log units), on the high side; low and high end bracket the measured number.
By their numbers in this assay, from the lowest: compounds 4, 2, 3 and 1 (each within the scatter of the next).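

In this assay the exchange for 3,5-dimethylphenyl gives a 2.0-fold lower number from compound 1 to compound 4 (0.29 log units; within the scatter) and a 1.5-fold lower number from compound 3 to compound 4 (0.19 log units; within the scatter) and a 1.2-fold lower number from compound 2 to compound 4 (0.06 log units; within the scatter) as its steps. So an aryl group of carbon only, with no fluorine, behaves on this carbonyl carbon like the groups before it, and none of the four compounds can be told apart from the others. Going by these compounds, whether an amine or a carboxylic acid on this aryl ring would move the number beyond the scatter stays open. Nothing given here accounts for how little the number responds to these exchanges.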